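The source may hold more compounds than are shown below. What is called first, only, known or untested is meant among the compounds shown, and "the series" means these compounds.

Working notes on the series. Of the compounds shown here, two of the shared core carry numbers so far. Compound 1 `CCOC(=O)C1CCN(c2ncnc(Oc3ccc(C(=O)CC(=O)OC)cc3)c2[N+](=O)[O-])CC1` bears a ((methoxycarbonyl)methyl)carbonyl group on the aromatic carbon; in a functional assay on HEK293 cells for agonist activity at Glucose-dependent insulinotropic receptor (Homo sapiens), read by cAMP accumulation (on this read-out higher numbers stand for an effect only at larger amounts of compound and lower numbers for an effect already at smaller amounts), compound 1 gives 1000 nM. Compound 2 `CCOC(=O)C1CCN(c2ncnc(Oc3ccc(CCC(C)=O)cc3)c2[N+](=O)[O-])CC1` differs at that place only by a 2-acetylethyl group; in this assay compound 2 gives 1700 nM. Among the measured compounds shown here, the single step between measured compounds is a 1.7-fold higher number from compound 1 to compound 2 (0.23 log units; within the scatter). For the measured compounds named here, compound 2 thus sits at the upper of the two numbers, but its only neighbour, compound 1, lies within the scatter of it, so the two are not separated.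

Compound 3 `CCOC(=O)C1CCN(c2ncnc(Oc3ccc(S(C)(=O)=O)cc3)c2[N+](=O)[O-])CC1` is the next member. Its difference from compound 2: methylsulfonyl in place of 2-acetylethyl on an aromatic carbon. Going by the values given here, no measured step covers an exchange of this kind; the one step in hand, from compound 1 to compound 2, concerns two other groups at the same place and stayed within the scatter. The data therefore give no direction. Compound 3 is expected to land near the numbers already seen, with an estimated step of a 1.1-fold lower number from compound 2 to compound 3 (0.05 log units; within the scatter) that need not exceed the scatter. The estimate for compound 3 in this assay is 1500 nM, within a range from 500 nM to 5000 nM.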

Compound 3, half-maximal effective concentration: 1900 nM
For compound 3 the middle estimate is 1.3-fold (0.10 log units) below the measured one; low and high end bracket the measured number.
By their numbers in this assay, from the lowest: compounds 1, 2 and 3 (each within the scatter of the next).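

In this assay, methylsulfonyl in place of 2-acetylethyl on an aromatic carbon para to a large group gives a 1.1-fold higher number from compound 2 to compound 3 (0.05 log units; within the scatter) and thus no separation between these two groups. Methylsulfonyl in place of ((methoxycarbonyl)methyl)carbonyl at the same place gives a 1.9-fold higher number from compound 1 to compound 3 (0.28 log units; within the scatter) and also stays within the scatter, so the three groups seen here at this place form one unseparated set, even though methylsulfonyl brings sulfur, and differs from 2-acetylethyl in its counts of heavy atoms and hydrogen-bond acceptors. No measurement in hand accounts for the closeness of these numbers.

Among the compounds shown here, it remains open whether an amine, a carboxylic acid or a longer chain at this place would give a step beyond the scatter, as all the steps so far lie within it and set no direction. On these data alone, it is equally open whether the closeness of these three groups would persist if the nitro group or the ethyl ester of the shared core were replaced.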